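The source may hold more compounds than are shown below. What is called first, only, known or untested is meant among the compounds shown, and "the series" means these compounds.

Compound 1 `COc1ccc(Nc2ncc3c(n2)N(C2CCCC2)CC(=O)N3C)cc1` is one of three measured members of a shared core. In a functional assay on MDA-MB-231 cells (Homo sapiens) for inhibition, read by MTT assay, with a stated time of 48 h (a lower number here means a stronger inhibitor, a higher number a weaker inhibitor), compound 1 gives only a limit, > 30000 nM, not a number. Compound 2 `CCN1C(=O)CN(C2CCCC2)c2nc(Nc3ccc(OC)cc3)ncc21` differs from it by a methyl in place of hydrogen on a saturated chain carbon bound to an amide-type nitrogen in a ring. In this assay compound 2 also gives only a limit, > 30000 nM. The step that the two limits leave unreadable from compound 1 to compound 2 therefore cannot be read in size or direction. Compound 3 `O=C1CN(C2CCCC2)c2nc(Nc3ccc(N4CCCCC4)cn3)ncc2N1` carries a piperidinyl group on another kind of aromatic ring and lacks the methyl on the amide-type nitrogen. In this assay compound 3 likewise gives only a limit, > 30000 nM. Among the compounds with values here, what the three measured values share is the limit of > 30000 nM in this assay, at which 3 of the 3 values shown sit, so no measured step supplies a readable size.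

Compound 4 `CN1C(=O)CN(C2CCCC2)c2nc(Nc3ccc(N4CCCCC4)cc3)ncc21` has not yet been measured. It differs from compound 1 by piperidin-1-yl in place of methoxy on an aromatic carbon. Within the data shown here, the single measured step bears on it only in that it, too, is unreadable, and the piperidinyl-bearing compound 3 sits at the same limit. Compound 4 is therefore expected to give 30000 nM, in a range from 8000 nM to 100000 nM. The estimated step of a number no higher from compound 1 to compound 4 (the limit leaves the size open) is expected to be none beyond the scatter, with a real chance that only a limit is reported again.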

Compound 4, half-maximal inhibitory concentration: 21200 nM
Compound 4: middle estimate off by 1.4-fold (0.15 log units), on the high side, and the stated range covers the measured number.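

In this assay compound 4 gives 21200 nM as a number, the only one among the compounds shown, so this aromatic carbon, para to a large group, is the first place where a change in the set yields a value that is not a limit. Piperidin-1-yl in place of methoxy gives an at least 1.4-fold lower number from compound 1 to compound 4 (0.15 log units; that floor lies within the scatter) and this figure is only a floor, so the real size of the change may be larger but is not fixed by these data. The other values remain limits, and the steps among them cannot be read: the limit of > 30000 nM in this assay, at which 3 of the 4 values shown sit.

What the compounds shown leave open is whether another amine on that aromatic carbon, such as piperazin-1-yl or morpholin-4-yl, or a carboxylic acid there, would give a number clearly apart from that of compound 4 in this assay. From the compounds shown here alone, it is also open whether the ethyl group on the amide-type nitrogen of compound 2 would behave as the methyl of compound 4 does once piperidin-1-yl takes the place of methoxy.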